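The source may report more compounds than this note shows. Statements on the series, on what has been measured and on what is new or still open speak of the compounds shown alone.

Measured compounds:
- compound 1, `Cc1ccc(-n2nncc2CN2C(=O)C3(C(C#N)=C(N)Oc4c3c3nc5ccccc5nc3c3ccccc43)c3ccccc32)cc1C`
- compound 2, `Cc1ccc(-n2nncc2CN2C(=O)C3(C(C#N)=C(N)Oc4c3c3nc5ccccc5nc3c3ccccc43)c3ccccc32)c(C)c1`

In a functional assay on HCT-116 cells (Homo sapiens) for antiproliferative activity, read by MTT assay, with a stated time of 48 h (a lower number here means a stronger inhibitor, a higher number a weaker inhibitor), compound 1 gives > 50000 nM, which is a limit of the assay rather than a number. In this assay compound 2 gives > 50000 nM, again a limit and not a number. Both compounds therefore sit at the limit of > 50000 nM in this assay, at which 2 of the 2 values shown sit, and the step that the two limits leave unreadable from compound 1 to compound 2 cannot be read, because the two limits hide whatever difference there may be. Where compound 2 stands on the numbers shown is thus only this: at the limit, with no measured activity to its name.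

Compound 3 is `Cc1ccc(Cl)cc1-n1nncc1CN1C(=O)C2(C(C#N)=C(N)Oc3c2c2nc4ccccc4nc2c2ccccc32)c2ccccc21`. The change is 5-chloro-2-methylphenyl in place of 2,4-dimethylphenyl on an aromatic nitrogen. For the measured compounds named here, the only measured step, from compound 1 to compound 2, is unreadable, so there is no step that bears on this change in a readable way. Going by the values given here, what remains is that both compounds measured so far sit at the limit, and the expectation for compound 3 is that it stays there too, with a step that the limit leaves unreadable from compound 2 to compound 3 expected to be no more than the scatter. Compound 3 is expected at 70000 nM, with a range from 20000 nM to 250000 nM.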

Compound 3, half-maximal inhibitory concentration: > 50000 nM
Compound 3 gave a limit, no number (the forecaster's own chance of this, stated with the estimate: 85%); the middle value lies beyond the limit too.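

In this assay compound 3 gives > 50000 nM, again a limit and not a number. Its steps from compound 1 and compound 2 therefore cannot be read, and all three compounds stand together: the limit of > 50000 nM in this assay, at which 3 of the 3 values shown sit. The compounds shown leave open whether any group on the aromatic nitrogen of this series can bring measurable activity in this assay.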